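The source may hold more compounds than are shown below. What is called first, only, known or untested is meant among the compounds shown, and "the series" means these compounds.

Compound 1 `CC(C)OC(=O)C1=C(C(F)(F)F)NC(=O)NC1c1ccoc1`: 37%
Compound 2 `CC1=C(C(=O)OC(C)C(F)(F)F)C(c2ccsc2)NC(=O)N1`: 1%
Compound 3 `CC1=C(C(=O)OC(C(F)(F)F)C(F)(F)F)C(c2ccco2)NC(=O)N1`: 1%

Of the compounds shown here, three have been measured in an assay on HEK293 cells for displacement of a labelled ligand from adenosine receptor A2b (Homo sapiens), read by radioligand binding, with a stated time of 30 min, tested at 1 uM; on this read-out lower numbers stand for less inhibition and higher numbers for more inhibition at the one concentration tested (going by the name of the read-out). Compound 1 gives 37%, the highest of the three numbers. Compound 2 gives 1%, and compound 3 gives 1%; each of these stands under compound 1 by a gap that lies beyond the usual scatter. For the measured compounds named here, compounds 2 and 3 each differ from compound 1 in more than one place, so no single step between measured compounds can be read from these numbers.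

Compound 4 `CC(C)OC(=O)C1=C(C(F)(F)F)NC(=O)NC1c1cccs1` has not yet been measured in this assay. It differs from compound 1 in one place only: thiophen-2-yl in place of furan-3-yl on a saturated ring carbon. Going by the values given here, no measured pair shows this change on its own, so the data give no step to lean on. With compound 1 as the only anchor, compound 4 is expected to stay close to it: the step of a number 2 percentage points lower from compound 1 to compound 4 (within the scatter) is estimated to be small, with no clear direction, and likely within the scatter. Compound 4 is therefore estimated at 35%, with a range from 10% to 60%.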

Compound 4, a percentage reported as inhibition, at one concentration (the size of the read-out at that concentration, not a potency): 19%
Compound 4: the middle estimate sits 16 percentage points above what was measured; measured number inside the range.
By their numbers in this assay, from the lowest: compounds 2 and 3 (each within the scatter of the next); then compound 4; then compound 1.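

In this assay, for the compounds shown here, the change from furan-3-yl to thiophen-2-yl on the saturated ring carbon gives the first single-place step in this set, a number 18 percentage points lower from compound 1 to compound 4 (beyond the scatter). It shows that the number at this position depends on which five-membered aromatic ring is attached, even though the two groups match in heavy-atom count, hydrogen-bond donors and acceptors, and net charge. The change replaces oxygen with sulfur and also alters the ring's point of attachment, and this single step cannot separate those two differences, while no measurement at hand accounts for the step.

The compounds shown leave open whether a phenyl or pyridin-3-yl ring at this position would give a number nearer that of compound 1 or that of compound 4. They also leave open whether the step from furan-3-yl to thiophen-2-yl would keep its size with a cyclopentyl ester in place of the isopropoxycarbonyl group, a question on which compound 2 and compound 3, which each differ from compound 1 in more than one place, cannot speak.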